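The source may report more compounds than this note shows. Statements on the series, on what has been measured and on what is new or still open speak of the compounds shown alone.

In an ADME assay on cells (Erythrocyte, Homo sapiens), read by spectrophotometry and hemolysis, with a stated time of 24 h (on this read-out higher numbers stand for weaker inhibition and lower numbers for stronger inhibition), compound 2 (`CC1(C)[N+]([O-])=c2ccc(COc3ccccc3/C=N\NC(=N)N)cc2=[N+]1[O-]`) gives 114 uM and compound 3 (`CC1(C)[N+]([O-])=c2ccc(COc3ccccc3/C=N\NC(=S)Nc3ccccc3)cc2=[N+]1[O-]`) gives 66 uM, two values that lie within the scatter of each other. Compound 1 (`CC(=O)c1ccccc1OCc1ccc2c(c1)=[N+]([O-])C(C)(C)[N+]=2[O-]`) reads < 50 uM, which is a limit of the assay and not a number.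

Compound 4 (`CC1(C)[N+]([O-])=c2ccc(COc3ccccc3/C=N\NC(N)=O)cc2=[N+]1[O-]`) differs from compound 3 in one place: a group of 3 heavy atoms (1 carbon, 1 nitrogen, 1 oxygen; no ring) in place of a group of 9 heavy atoms (7 carbon, 1 nitrogen, 1 sulfur; one six-membered aromatic ring of carbon only), on an amine nitrogen. Two measured steps offer guidance. The first is an at least 2.2-fold higher number from compound 1 to compound 2 (0.35 log units; beyond the scatter), but it rests on a limit and involves a change elsewhere in the structure, so it says little here. The second is a 1.7-fold lower number from compound 2 to compound 3 (0.24 log units; within the scatter), and it is the closer guide: it also places the 9-atom group on the amine nitrogen in place of a group of 3 heavy atoms. Among the compounds with values here, compound 4 reverses that kind of swap, although its small group is carbamoyl and not the one in compound 2. A shift beyond the scatter in this assay is therefore not expected, and the expected step is a 1.4-fold higher number from compound 3 to compound 4 (0.13 log units; within the scatter). The estimate for compound 4 is 90 uM, with an expected range from 40 uM to 200 uM.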

Compound 4, concentration for 50% inhibition: 50 uM
Compound 4: the middle estimate sits 1.8-fold (0.26 log units) above what was measured, within the range that was stated.
By their numbers in this assay, from the lowest: compounds 4, 3 and 2 (each within the scatter of the next, the first and the last beyond it).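

On the amine nitrogen, carbamoyl in place of the group of 9 heavy atoms with its six-membered aromatic ring gives a 1.3-fold lower number from compound 3 to compound 4 (0.12 log units; within the scatter), so in this assay these two very different groups cannot be told apart. The new finding is that two groups of 3 heavy atoms can be told apart at this place: with one nitrogen replaced by oxygen, the swap gives a 2.3-fold lower number from compound 2 to compound 4 (0.36 log units; beyond the scatter), so heavy-atom count alone does not set the number here. Compound 1 reads as a limit and not a number. The change on the aromatic carbon gives a number no lower from compound 1 to compound 4 (the limit leaves the size open), and the size of this step cannot be read because of that limit: the limit of < 50 uM in this assay, at which 1 of the 4 values shown sits.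

From the compounds shown here alone, compound 3 differs from compound 4 in both its sulfur and its aromatic ring, so the part each plays remains open. Also open, going by these compounds, is how a methyl group or a longer chain on this amine nitrogen would read in this assay.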